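Swapping a dichlorobenzyl for a fluorobenzyl on a shared core

The source may report more compounds than this note shows. Statements on the series, on what has been measured and on what is new or still open speak of the compounds shown alone.

Compound 1 `Nc1cc(N)c2nc(-c3ccccc3)c(NCc3ccc(Cl)c(Cl)c3)nc2c1`, compound 2 `COc1cc(CNc2nc3cc(N)cc(N)c3nc2-c2ccccc2)cc(OC)c1OC` and compound 3 `CCOC(=O)[C@H](CCC(=O)O)NC(=O)c1ccc(Oc2nc3cc(N)cc(N)c3nc2-c2ccccc2)cc1` share one core and were tested in a functional assay on IGROV-1 cells (Homo sapiens) for inhibition, read by sulforhodamine B assay, with a stated time of 48 h; a lower number here means a stronger inhibitor of growth, a higher number a weaker inhibitor of growth. Compound 1 gives 1950 nM, the lowest of the three numbers. Compound 2 gives 9120 nM and compound 3 gives 18200 nM, both lying beyond the usual scatter from compound 1. Compound 4 `Nc1cc(N)c2nc(-c3ccccc3)c(NCc3ccc(F)cc3)nc2c1` has not been measured; it differs from compound 1 by 4-fluorophenyl in place of 3,4-dichlorophenyl on a saturated chain carbon bound to a nitrogen on an aromatic ring. For the measured compounds named here, no measured pair shows this kind of exchange, so its effect is unknown here. The exchange is expected to weaken growth inhibition modestly, and the step from compound 1 to compound 4 is estimated as a 2.3-fold higher number from compound 1 to compound 4 (0.36 log units; beyond the scatter). Compound 4 is expected to give 4500 nM, within a range from 1500 nM to 14000 nM.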

Compound 4, concentration for 50% growth inhibition: 3090 nM
The estimate for compound 4 lay 1.5-fold (0.16 log units) above the measured number, within the range that was stated.
By their numbers in this assay, from the lowest: compounds 1 and 4 (each within the scatter of the next); then compounds 2 and 3 (each within the scatter of the next).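

In this assay, putting a 4-fluorobenzyl in place of the 3,4-dichlorobenzyl gives a 1.6-fold higher number from compound 1 to compound 4 (0.20 log units; within the scatter). For the compounds shown here, this is the first pair here that differs in one place, and at this position the two halogen patterns cannot be told apart in growth inhibition. Nothing measured here offers an explanation for this result.

From the compounds shown here alone, whether this position needs a halogen at all stays open. A plain benzyl, a benzyl carrying an amine or a carboxylic acid, and a longer chain holding the ring are not among the compounds shown.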